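This account rests on a few compounds, and the source may have more. Where it says the series, first, only, none or still open, it means among the compounds named here.

Measured in a functional assay with Oryctolagus cuniculus as the target; on this read-out higher numbers stand for weaker inhibition and lower numbers for stronger inhibition:
Compound 1 `COc1ccc(-c2nc(/N=C(\N)n3ccnc3)sc2-c2ccc(OC)cc2)cc1`: > 100 nM (a limit)
Compound 2 `COc1ccc(-c2nc(CNC(=O)NC(C)C)sc2-c2ccc(OC)cc2)cc1`: 42 nM
Compound 3 `COc1ccc(-c2nc(C(=O)N(C)C)sc2-c2ccc(OC)cc2)cc1`: < 100 nM (a limit)

Compound 3 stands at < 100 nM, which is a limit and not a number. Compound 4 `CCOC(=O)/C(C#N)=C/c1nc(-c2ccc(OC)cc2)c(-c2ccc(OC)cc2)s1` carries 2-cyano-2-(ethoxycarbonyl)ethenyl in place of dimethylcarbamoyl on an aromatic carbon. Among the compounds with values here, no measured step makes this exact change. Within the data shown here, the one readable guide is an at least 2.3-fold lower number from compound 1 to compound 2 (0.37 log units; beyond the scatter), which shows that a change on this carbon can matter. The other two are open: a number no higher from compound 1 to compound 3 (the limit leaves the size open) and a step that the limit leaves unreadable from compound 2 to compound 3. The expected step in this assay is a number no lower from compound 3 to compound 4 (the limit leaves the size open), with neither direction firmly favoured. Compound 4 is estimated at 100 nM, with an expected range of 15 nM to 600 nM.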

Compound 4, half-maximal inhibitory concentration: < 10 nM
Compound 4 gave a limit, no number; the forecaster's own chance of this, stated with the estimate: 45%; at least 10-fold (1.00 log units) between middle value and limit.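

In this assay, within the data shown here, 2-cyano-2-(ethoxycarbonyl)ethenyl on this aromatic carbon improves on ((isopropylcarbamoyl)amino)methyl, the one group with a measured number, showing an at least 4.2-fold lower number from compound 2 to compound 4 (0.62 log units; beyond the scatter). It also shows an at least 10-fold lower number from compound 1 to compound 4 (1.00 log units; beyond the scatter). The step from dimethylcarbamoyl cannot be read, and the value of compound 4 is itself a limit: the limit of < 10 nM in this assay, at which 1 of the 4 values shown sits.

On these data alone, how far compound 4 reaches therefore stays open. Also open, as far as these compounds go, is which part of the new group matters, for instance whether a carboxylic acid in place of the ethyl ester, or a plain ethenyl chain without the nitrile, would keep the gain.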